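The compounds below may be only part of what the source reports. "The series", "measured", "known", "first", "only" and "open" are said of these compounds alone.

In a functional assay on blood (Homo sapiens), with a stated time of 60 min, in the presence of a further agent that is not named here (on this read-out higher numbers stand for an effect only at larger amounts of compound and lower numbers for an effect already at smaller amounts), compound 1 `O=C(OCc1ccccc1)C1(S(=O)(=O)c2ccc(Oc3ccc(OC(F)(F)F)cc3)cc2)CCC2(CCNCC2)C1` gives > 15000 nM, which is a limit of the assay and not a number. Compound 2 `O=C1CN(C(=O)C2(S(=O)(=O)c3ccc(Oc4ccc(OC(F)(F)F)cc4)cc3)CCC3(CCNCC3)C2)CCN1` gives 7500 nM. Among the measured compounds shown here, compound 3 `Nc1ccccc1NC(=O)C1(S(=O)(=O)c2ccc(Oc3ccc(OC(F)(F)F)cc3)cc2)CCC2(CCNCC2)C1` gives 900 nM, the lowest number so far. Changing the group on the carbonyl carbon gave an at least 16-fold lower number from compound 1 to compound 3 (1.22 log units; beyond the scatter) and an 8.3-fold lower number from compound 2 to compound 3 (0.92 log units; beyond the scatter), while the floor of an at least 2.0-fold lower number from compound 1 to compound 2 (0.30 log units; that floor lies within the scatter) stays within the scatter.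

Compound 4 `COc1ccc(N)c(NC(=O)C2(S(=O)(=O)c3ccc(Oc4ccc(OC(F)(F)F)cc4)cc3)CCC3(CCNCC3)C2)c1` differs from compound 3 by methoxy in place of hydrogen on an aromatic carbon, meta to a large group and para to an amino group (methoxy in place of hydrogen on an aromatic carbon). Each measured step replaces the whole group on the carbonyl carbon, and none tests a substituent on this aromatic ring. They therefore give no direct size for this change. Compound 3 keeps the (2-aminophenyl)amino group, and an 8.3-fold lower number from compound 2 to compound 3 (0.92 log units; beyond the scatter) is the closest guide to the sensitivity of this assay to this part of the structure. A far smaller edit is made here, so no shift beyond the scatter is expected, and the range stays wide. The expected result is a 1.1-fold higher number from compound 3 to compound 4 (0.05 log units; within the scatter). For compound 4 the estimated value is 1000 nM, with an expected range from 350 nM to 3000 nM.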

Compound 4, half-maximal effective concentration: 3700 nM
Estimate against measurement, compound 4: 3.7-fold (0.57 log units) below, and the stated range ends below it.
By their numbers in this assay, from the lowest: compound 3; then compound 4; then compound 2. At a limit, above all of these: compound 1.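

In this assay, the aromatic ring of the (2-aminophenyl)amino group proves sensitive to a small edit: methoxy on the carbon para to the amino group gives a 4.1-fold higher number from compound 3 to compound 4 (0.61 log units; beyond the scatter). The (2-amino-5-methoxyphenyl)amino group in place of 3-oxopiperazin-1-yl still gives a 2.0-fold lower number from compound 2 to compound 4 (0.31 log units; beyond the scatter), and in place of benzyloxy it gives an at least 4.0-fold lower number from compound 1 to compound 4 (0.60 log units; beyond the scatter). That last step is only a floor, as compound 1 stands at a limit of the assay and not at a number: the limit of > 15000 nM in this assay, at which 1 of the 4 values shown sits.

As far as these compounds go, whether the shift belongs to methoxy itself or to any group on this carbon stays open, and fluorine or methyl there would separate the two. The compounds shown also leave open how methoxy would read out on the other carbons of this ring.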